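Dropping a Methoxy on the Aryl Ketone Side

This account rests on a few compounds, and the source may have more. Where it says the series, first, only, none or still open, it means among the compounds named here.

Compound 1, `COc1ccc(-c2cc(/C=C/C(=O)c3ccc(N)cc3)[nH]n2)cc1`: 13100 nM
Compound 2, `COc1ccc(-c2cc(/C=C/C(=O)c3ccc(N)cc3)[nH]n2)cc1OC`: 19300 nM
Compound 3, `COc1cc(C(=O)/C=C/c2cc(-c3cc(OC)c(OC)c(OC)c3)n[nH]2)cc(OC)c1OC`: 9900 nM

Of the compounds shown here, three have been measured in a functional assay on NCI-H23 cells (Homo sapiens) for inhibition, read by sulforhodamine B assay, with a stated time of 48 h; a higher number here means a weaker inhibitor of growth, a lower number a stronger inhibitor of growth. Compound 2 and compound 1 share a core and differ in one place, (hydrogen in place of methoxy on an aromatic carbon); the step was a 1.5-fold lower number from compound 2 to compound 1 (0.17 log units; within the scatter). Compound 3 carries a different core; the difference between the two cores is not broken down here, and its value and those of compound 1 and compound 2 lie within the scatter of one another. Compound 4, `COc1ccc(-c2cc(/C=C/C(=O)c3cc(OC)c(OC)c(OC)c3)[nH]n2)cc1OC`, is not yet measured; it differs from compound 3 by hydrogen in place of methoxy on an aromatic carbon. The surroundings are not identical to the first change: here the carbon is meta to a methoxy group as well, so this is the same kind of change, not the same. Resting on the step of a 1.5-fold lower number from compound 2 to compound 1 (0.17 log units; within the scatter), the expected step is a 1.3-fold lower number from compound 3 to compound 4 (0.12 log units; within the scatter). Compound 4 is therefore estimated to give 7500 nM in this assay, between 3000 nM and 18000 nM.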

Compound 4, concentration for total growth inhibition: 4910 nM
Compound 4: middle estimate off by 1.5-fold (0.18 log units), on the high side, within the range that was stated.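

In this assay, putting hydrogen in place of methoxy on an aromatic carbon gives a 2.0-fold lower number from compound 3 to compound 4 (0.30 log units; within the scatter). Set beside the same change on the other core, the two steps agree: the same change on two cores in this assay, a 1.5-fold lower number (0.17 log units; within the scatter) from compound 2 to compound 1 and a 2.0-fold lower number (0.30 log units; within the scatter) from compound 3 to compound 4, 1.4-fold (0.14 log units) apart, within the scatter of two such steps So the change carries across these two cores with no difference that can be told apart, but each step on its own also lies within the scatter, and neither shows that removing a methoxy truly alters growth inhibition, nor can two pairs speak for other cores.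

The compounds shown leave open what a different group on that aromatic carbon would do, such as a hydroxyl or a fluorine. A step clearly beyond the scatter also remains to be seen.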